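Dropping the Methyl From the Benzyl Group

The source may report more compounds than this note shows. Statements on the series, on what has been measured and on what is new or still open speak of the compounds shown alone.

Measured compounds:
compound 1, `O=C(CCC1C(=O)N(c2ccc(Cl)cc2)C(=O)N1Cc1ccc(Br)cc1)Nc1ccc(C(=O)NO)cc1`: in an assay on isolated protein for inhibition of histone deacetylase 4 (Homo sapiens), read by fluorescence, with stated times of 5 min and 60 min (a lower number here means a stronger inhibitor, a higher number a weaker inhibitor), compound 1 gives > 100000 nM, a limit of the assay.
compound 2, `Cc1ccc(CN2C(=O)N(c3ccc(Cl)cc3)C(=O)C2CCC(=O)Nc2ccc(C(=O)NO)cc2)cc1`: in this assay compound 2 gives > 100000 nM, also a limit.

Compound 2 therefore stands at the limit, with no number of its own. The step that the two limits leave unreadable from compound 1 to compound 2 cannot be read because both values sit at the limit of > 100000 nM in this assay, at which 2 of the 2 values shown sit. Compound 3, `O=C(CCC1C(=O)N(c2ccc(Cl)cc2)C(=O)N1Cc1ccccc1)Nc1ccc(C(=O)NO)cc1`, differs from compound 2 by hydrogen in place of methyl on an aromatic carbon. Among the measured compounds shown here, the only measured step is unreadable, so no size or direction is expected in this assay beyond the scatter. Compound 3 is estimated at 150000 nM, within 30000 nM to 600000 nM. This estimate means an expected step that the limit leaves unreadable from compound 2 to compound 3.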

Compound 3, half-maximal inhibitory concentration: 27000 nM
The estimate for compound 3 lay 5.6-fold (0.74 log units) above the measured number, outside the stated range (below it).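

In this assay, the change from 4-methylbenzyl to benzyl gives an at least 3.7-fold lower number from compound 2 to compound 3 (0.56 log units; beyond the scatter), and hydrogen in place of bromo at the same place gives an at least 3.7-fold lower number from compound 1 to compound 3 (0.56 log units; beyond the scatter). This place on the benzyl group therefore does respond to change, which the earlier pair could not show. Of the three groups shown here, only hydrogen gives a readable number, while methyl and bromo both stay at the limit.

From the compounds shown here alone, the true size of both steps stays open because only a limit anchors each one: the limit of > 100000 nM in this assay, at which 2 of the 3 values shown sit. Whether a fluorine or a hydroxyl at this place would also give a readable number also remains open.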